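The source may hold more compounds than are shown below. What is called first, only, known or untested is meant among the compounds shown, and "the series" means these compounds.

Working notes on the series. Compound 1 `O=C(N1CCC(F)CC1)N1CC(c2nc(-c3cccc(Cl)c3)no2)C1` is a urea carrying a 4-fluoropiperidin-1-yl group on the carbonyl. In an assay on HEK293 cells for negative allosteric modulation of metabotropic glutamate receptor 5 (Homo sapiens), read by FLIPR (a higher number here means a weaker inhibitor, a lower number a stronger inhibitor), compound 1 gives only a limit, > 10000 nM, so its standing is known merely as the weak end of the range shown. That value sits at the limit of > 10000 nM in this assay, at which 1 of the 2 values shown sits, and no number lies behind it. Compound 2 `Cc1ccc(S(=O)(=O)N2CC(c3nc(-c4cccc(Cl)c4)no3)C2)cc1` replaces the urea with a sulfonyl link to a tolyl ring. In this assay compound 2 gives 920 nM, a measured number rather than a limit, which shows that the shared core can reach moderate inhibition when the group on the azetidine nitrogen is changed. Compound 3 `CC1CCN(C(=O)N2CC(c3nc(-c4cccc(Cl)c4)no3)C2)C1` is still to be measured. It differs from compound 1 by 3-methylpyrrolidin-1-yl in place of 4-fluoropiperidin-1-yl on a carbonyl carbon, a change confined to the amine half of the urea. Within the data shown here, no step between two measured compounds is available to calibrate this exchange. The expected step of an at least 1.1-fold lower number from compound 1 to compound 3 (0.04 log units; that floor lies within the scatter) is taken as none beyond the scatter, with a small gain allowed. Compound 3 is estimated at 9000 nM, within 2500 nM to 30000 nM.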

Compound 3, half-maximal inhibitory concentration: > 10000 nM
Compound 3 was reported as a limit (the forecaster's own chance of this, stated with the estimate: 60%); middle value at least 1.1-fold (0.04 log units) away from the limit.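

In this assay compound 3 gives > 10000 nM, a limit and not a number. Among these compounds, no step from compound 1 to compound 3 can be read, since both compounds stand only as limits: the limit of > 10000 nM in this assay, at which 2 of the 3 values shown sit. The compounds shown leave open how far either urea lies from that limit, and whether any amine group on the urea carbonyl gives a measured number in this assay.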